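Swapping the sulfonamide for a urea in compound 4

The source may hold more compounds than are shown below. What is called first, only, known or untested is meant among the compounds shown, and "the series" means these compounds.

Compound 1, `O=C(Nc1ccc(-c2noc(-c3cccc(NS(=O)(=O)c4ccccc4)c3)n2)c(Cl)c1)c1cccnc1`: > 10000 nM
Compound 2, `CC(=O)Nc1ccc(S(=O)(=O)Nc2cccc(-c3nc(-c4ccc(NC(=O)c5cccnc5)cc4Cl)no3)c2)cc1`: 2500 nM
Compound 3, `NC(=O)Nc1ccc(S(=O)(=O)Nc2cccc(-c3nc(-c4ccc(NC(=O)c5cccnc5)cc4Cl)no3)c2)cc1`: 2800 nM

In a functional assay on MDA-MB-231 cells (Homo sapiens) for antiproliferative activity, read by MTT assay, with a stated time of 72 h (on this read-out lower numbers stand for stronger inhibition and higher numbers for weaker inhibition), compound 1 reaches only a limit, > 10000 nM, so no number is known for it (the limit of > 10000 nM in this assay, at which 1 of the 3 values shown sits). Compound 2 gives 2500 nM in this assay, and compound 3 gives 2800 nM; both carry an extra group on the outer ring of the sulfonamide, and the steps of an at least 4.0-fold lower number from compound 1 to compound 2 (0.60 log units; beyond the scatter) and an at least 3.5-fold lower number from compound 1 to compound 3 (0.55 log units; beyond the scatter) show that each addition brought a weaker inhibitor into the measurable range. Between the two, the step of a 1.1-fold higher number from compound 2 to compound 3 (0.05 log units; within the scatter) is within the scatter.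

Compound 4, `COc1cccc(NC(=O)Nc2cccc(-c3nc(-c4ccc(NC(=O)c5cccnc5)cc4Cl)no3)c2)c1`, is not yet measured. It differs from compound 1 in another way: (3-methoxyphenyl)carbamoyl in place of phenylsulfonyl on a nitrogen on an aromatic ring. Neither measured step alters this linking group, so they bear on the change only loosely, showing that this part of the molecule can be varied and still give a number. A value near those of compound 2 and compound 3 is therefore expected for compound 4, at 4000 nM with a range from 1500 nM to 12000 nM. This means an expected step of an at least 2.5-fold lower number from compound 1 to compound 4 (0.39 log units; beyond the scatter), with a real chance that only a limit is again reported.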

Compound 4, half-maximal inhibitory concentration: 6700 nM
Compound 4: middle estimate off by 1.7-fold (0.22 log units), on the low side, within the range that was stated.
By their numbers in this assay, from the lowest: compounds 2 and 3 (each within the scatter of the next); then compound 4. At a limit, above all of these: compound 1.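

Within the data shown here, compound 4 shows that a urea-type link, ((3-methoxyphenyl)carbamoyl)amino in place of (phenylsulfonyl)amino, still gives a measured number on the shared core, whereas the earlier compounds varied only the outer ring and kept the sulfonamide. In this assay, the step is an at least 1.4-fold lower number from compound 1 to compound 4 (0.17 log units; that floor lies within the scatter), so the swap cannot be said to have made a real difference, nor can a larger one be ruled out. Compound 1 stands only at a limit, which leaves the comparison open at one end: the limit of > 10000 nM in this assay, at which 1 of the 4 values shown sits.

The swap changes the link and brings in a methoxy group together, so the compounds shown cannot separate the contribution of each. Going by these compounds, it also remains open how a urea with an unsubstituted phenyl ring, or one carrying an amine or a carboxylic acid on that ring, would behave.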